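Swapping the thiophene attachment with no measured starting point

The source may hold more compounds than are shown below. What is called first, only, known or untested is meant among the compounds shown, and "the series" means these compounds.

Compound 1 `N#Cc1c(-c2ccsc2)cc(-c2ccc(Br)cc2)[nH]c1=N` - "not determined" (no result reported)
Compound 2 `CCOc1ccc(-c2cc(-c3ccc(Br)cc3)[nH]c(=N)c2C#N)cc1` - 14200 nM

In a functional assay on HT-29 cells (Homo sapiens) for inhibition, read by luminescence, with a stated time of 72 h (on this read-out lower numbers stand for stronger inhibition and higher numbers for weaker inhibition), compound 1 has no single number, so compound 2 (14200 nM) is the only measured anchor. Compound 3 `N#Cc1c(-c2cccs2)cc(-c2ccc(Br)cc2)[nH]c1=N` has thiophen-2-yl in place of thiophen-3-yl on an aromatic carbon of the core of compound 1 (thiophen-2-yl in place of thiophen-3-yl on an aromatic carbon). The two have the same atoms, joined differently. Among the compounds with values here, no measured pair shows what such a swap does, so the step in this assay is expected to be none beyond the scatter. Compound 3 is estimated at 10000 nM (expected range 3000 nM to 30000 nM).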

Compound 3, half-maximal inhibitory concentration: 35000 nM
Compound 3: the middle estimate sits 3.5-fold (0.54 log units) below what was measured; the whole stated range lies below it.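

Within the data shown here, compound 1 and compound 3 give no step to read in this assay here, as compound 1 has no single number. On these data alone, what swapping thiophen-3-yl for thiophen-2-yl does to inhibition stays open, and no evidence bears on this result.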